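Aminopyrimidinol heteroaryl replacement in CCR9 antagonist sulfonamides

A few compounds are considered here, and "the series" means these few. Any claim that something is new, unique, unknown or untested is made for them only; others in the source may bear on it.

Measured so far:
compound 1 `CC(C)(C)c1ccc(S(=O)(=O)Nc2ccc(Cl)cc2-c2nccc(C(N)=O)c2O)cc1`, 52 nM
compound 2 `CC(C)(C)c1ccc(S(=O)(=O)Nc2ccc(Cl)cc2-c2nc(N)ncc2O)cc1`, 4 nM

In a functional assay on isolated protein for antagonist activity at C-C chemokine receptor type 9 (Homo sapiens), read by calcium flux, with a stated time of 10 min (a lower number here means a stronger inhibitor, a higher number a weaker inhibitor), compound 2 gives the lowest of the two numbers; compound 1 sits at a 13-fold lower number from compound 1 to compound 2 (1.11 log units; beyond the scatter) from it. Compound 3 `CN(C)c1ncnc(-c2cc(Cl)ccc2NS(=O)(=O)c2ccc(C(C)(C)C)cc2)c1O` carries the change (a group of 10 heavy atoms (6 carbon, 3 nitrogen, 1 oxygen; one six-membered aromatic ring with 2 hetero atoms) in place of a group of 8 heavy atoms (4 carbon, 3 nitrogen, 1 oxygen; one six-membered aromatic ring with 2 hetero atoms), on an aromatic carbon). Within the data shown here, no measured step bears directly on this exchange; the single step known, from compound 1 to compound 2, concerns a different heteroaryl swap and was large. With one hydrogen-bond donor lost and two carbons added, a modest weakening is expected, a 2.5-fold higher number from compound 2 to compound 3 (0.40 log units; beyond the scatter), within or slightly beyond the scatter. Compound 3 is estimated at 10 nM, range 3 nM to 40 nM.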

Compound 3, half-maximal inhibitory concentration: 9 nM
For compound 3 the middle estimate is 1.1-fold (0.05 log units) above the measured one; the range from low to high includes it.
By their numbers in this assay, from the lowest: compound 2; then compound 3; then compound 1.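

In this assay, the group of 10 heavy atoms, with 1 hydrogen-bond donor against 2 in the group it replaces, gives only a modest step on this aromatic carbon, a 2.3-fold higher number from compound 2 to compound 3 (0.35 log units; beyond the scatter). Much of the earlier gain survives this change, a 5.8-fold lower number from compound 1 to compound 3 (0.76 log units; beyond the scatter). Nothing available accounts for either step.

Open, going by these compounds, is how far this place tolerates larger substituents on the heteroaryl ring, such as a morpholine or a piperidine. Also open, on these data alone, is whether a carboxylic acid there would hold the number.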